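Removing the side-chain methyl from compound 1

This account rests on a few compounds, and the source may have more. Where it says the series, first, only, none or still open, it means among the compounds named here.

Going by the values given here, in a functional assay on MDA-MB-435S cells (Homo sapiens) for cytotoxicity, read by MTT assay (on this read-out lower numbers stand for stronger inhibition and higher numbers for weaker inhibition), compound 1 (`CCOC(=O)C(C)Oc1cc(O)c2c(=O)c(O)c(-c3ccc(OC)cc3)oc2c1CC=C(C)C`) gives 2500 nM, the lowest of the three numbers so far. Compound 2 (`COc1ccc(-c2oc3c(CC=C(C)C)c(OCCCOC(=O)CCCC(=O)O)cc(O)c3c(=O)c2OCCCOC(=O)CCCC(=O)O)cc1`) gives 8100 nM and compound 3 (`COc1ccc(-c2oc3c(CC=C(C)C)c(OCCCC(=O)O)cc(O)c3c(=O)c2OCCCC(=O)O)cc1`) gives 31100 nM, both beyond the scatter from compound 1. Compound 4 (`CCOC(=O)COc1cc(O)c2c(=O)c(O)c(-c3ccc(OC)cc3)oc2c1CC=C(C)C`) is not yet measured. Its change from compound 1 is hydrogen in place of methyl on a saturated chain carbon bound to a carbonyl carbon and an oxygen on an aromatic ring. Among the compounds with values here, no measured pair shows this change, so the expectation rests on the value of compound 1 alone. The step expected in this assay is small, with no direction beyond the scatter: a 1.2-fold higher number from compound 1 to compound 4 (0.08 log units; within the scatter). For compound 4 the estimate is 3000 nM, with an expected range of 1200 nM to 7500 nM.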

Compound 4, half-maximal inhibitory concentration: 5300 nM
Beside the measured number, compound 4's estimate is 1.8-fold (0.25 log units) below it; the range from low to high includes it.
By their numbers in this assay, from the lowest: compound 1; then compounds 4 and 2 (each within the scatter of the next); then compound 3.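

In this assay, going by these compounds alone, the methyl on the saturated chain carbon bound to a carbonyl carbon and an oxygen on an aromatic ring matters: replacing it with hydrogen gives a 2.1-fold higher number from compound 1 to compound 4 (0.33 log units; beyond the scatter) as the first single-place step. The step is modest, but it places 1-(ethoxycarbonyl)ethoxy ahead of (ethoxycarbonyl)methoxy on this core. No measured property bears on this step. From the compounds shown here alone, whether an ethyl or isopropyl group on that carbon would lower the number further remains open.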